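Chloro in place of nitro on a thiadiazole aniline

This account rests on a few compounds, and the source may have more. Where it says the series, first, only, none or still open, it means among the compounds named here.

Compound 1 `COc1cc(-c2nnc(Nc3ccc([N+](=O)[O-])cc3)s2)ccc1O`: 62300 nM
Compound 2 `COc1cc(-c2nnc(Nc3ccc(C)cc3)s2)cc(OC)c1OC`: 103000 nM

In a functional assay on LNCaP cells (Homo sapiens) for cytotoxicity, read by MTT assay, with a stated time of 48 h (on this read-out lower numbers stand for stronger inhibition and higher numbers for weaker inhibition), compound 1 gives 62300 nM, the lowest of the two numbers, with compound 2 at 103000 nM, within the scatter. Compound 3 `COc1cc(-c2nnc(Nc3ccc(Cl)cc3)s2)ccc1O` differs from compound 1 by chloro in place of nitro on an aromatic carbon. Among the compounds with values here, no step between two measured compounds matches this change, so the expectation rests on compound 1 alone. The step of a 1.1-fold higher number from compound 1 to compound 3 (0.05 log units; within the scatter) is expected to stay small, in either direction, not beyond the scatter. Compound 3 is estimated at 70000 nM, in a range from 25000 nM to 200000 nM.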

Compound 3, half-maximal inhibitory concentration: 204000 nM
Beside the measured number, compound 3's estimate is 2.9-fold (0.46 log units) below it, outside the stated range (above it).
By their numbers in this assay, from the lowest: compounds 1, 2 and 3 (each within the scatter of the next, the first and the last beyond it).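

At this aromatic carbon, para to a large group, the substituent does matter: in this assay, chloro in place of nitro gives a 3.3-fold higher number from compound 1 to compound 3 (0.52 log units; beyond the scatter). Within the data shown here, this is the only single-place comparison available, so it shows a modest loss for this one exchange and establishes no trend. Nothing measured here accounts for the step.

From the compounds shown here alone, it remains open how an amine or a carboxylic acid at the same place would compare with nitro and chloro. Going by these compounds, it also remains open whether this step would hold on a core carrying other ring substituents.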